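Lactone-to-lactam change on the trimethoxystyryl dihydropyranone series

This account rests on a few compounds, and the source may have more. Where it says the series, first, only, none or still open, it means among the compounds named here.

Compound 1 `COc1ccc(/C=C/C2CC=CC(=O)O2)c(OC)c1`: 5.6 uM
Compound 2 `COc1ccc(/C=C/C2CC=CC(=O)O2)cc1OC`: 16.8 uM
Compound 3 `COc1cc(OC)c(OC)cc1/C=C/C1CC=CC(=O)O1`: 7.2 uM

Three compounds have numbers in a functional assay on OVCAR-3 cells (Homo sapiens) for inhibition, read by sulforhodamine B assay, with a stated time of 48 h; on this read-out higher numbers stand for weaker inhibition of growth and lower numbers for stronger inhibition of growth. Compound 3 gives 7.2 uM and stands second highest of the three, nearest to compound 1 and furthest from compound 2. The two measured steps both add a methoxy in place of hydrogen on an aromatic carbon: a 1.3-fold higher number from compound 1 to compound 3 (0.11 log units; within the scatter), and a 2.3-fold lower number from compound 2 to compound 3 (0.37 log units; beyond the scatter).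

Compound 4 `COc1cc(OC)c(OC)cc1/C=C/C1CC=CC(=O)N1` is not yet measured. It differs from compound 3 at a double-bonded chain carbon bound to a double-bonded chain carbon: a group of 7 heavy atoms (5 carbon, 1 nitrogen, 1 oxygen; one six-membered non-aromatic ring with 1 hetero atom) in place of a group of 7 heavy atoms (5 carbon, 2 oxygen; one six-membered non-aromatic ring with 1 hetero atom), on a double-bonded chain carbon bound to a double-bonded chain carbon. Within the data shown here, neither measured step concerns this part of the molecule; both touch only the aromatic ring, so no step in this assay bears on the change from compound 3 to compound 4. The expectation therefore rests on compound 3 alone as the starting point, with a wide range on either side. A weaker growth inhibition is expected for compound 4, so the step is estimated as a 4.2-fold higher number from compound 3 to compound 4 (0.62 log units; beyond the scatter). Compound 4 is estimated at 30 uM, within a range from 7 uM to 150 uM.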

Compound 4, concentration for growth inhibition (reported as GI): > 864 uM
Compound 4: only a limit was reported; the forecaster's own chance of this, stated with the estimate: 20%; middle value at least 28-fold (1.45 log units) from the limit.
By their numbers in this assay, from the lowest: compounds 1 and 3 (each within the scatter of the next); then compound 2. At a limit, above all of these: compound 4.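

In this assay compound 4 is reported only as a limit: the limit of > 864 uM in this assay, at which 1 of the 4 values shown sits.

Exchanging the group on a double-bonded chain carbon bound to a double-bonded chain carbon, with a nitrogen-containing ring group entering for the ring group of carbon and oxygen alone, gives an at least 120-fold higher number from compound 3 to compound 4 (2.07 log units; beyond the scatter), so growth inhibition in this series depends strongly on this part of the molecule. The earlier steps shown here touched only the aromatic ring and were far smaller, with a 1.3-fold higher number from compound 1 to compound 3 (0.11 log units; within the scatter) and a 2.3-fold lower number from compound 2 to compound 3 (0.37 log units; beyond the scatter), so the methoxy pattern tunes the number only modestly while this group largely decides whether a measurable number is obtained at all.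

The data do not separate the loss of the ring oxygen from the gain of the amide hydrogen, and a methyl group in place of the amide hydrogen would address that question directly. On these data alone, the step also rests on a single pair, so it remains open whether the same exchange on the dimethoxy compounds, compound 1 and compound 2, would have an equally large effect.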